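Swapping an Ether Chain for a Sulfur Substituent

The source may hold more compounds than are shown below. What is called first, only, known or untested is meant among the compounds shown, and "the series" means these compounds.

In an ADME assay on MOLT-3 cells (Homo sapiens) for cytotoxicity, with a stated time of 7 days (on this read-out higher numbers stand for lower toxicity in this test and lower numbers for higher toxicity in this test), compound 1, `COCCOc1nc(N)nc2c1ncn2/C=C1/CC1(CO)CO`, gives only a limit, > 20000 nM. Compound 2, `CCCCCCCCOc1nc(N)nc2c1ncn2/C=C1/CC1(CO)CO`, likewise stops at a limit of > 20000 nM. Compound 3, `CCCCCOc1nc(N)nc2c1ncn2/C=C1/CC1(CO)CO`, also reaches only a limit of > 20000 nM. Because all three values sit at the limit of > 20000 nM in this assay, at which 3 of the 3 values shown sit, the steps between them cannot be sized: a step that the two limits leave unreadable from compound 1 to compound 2, a step that the two limits leave unreadable from compound 1 to compound 3 and a step that the two limits leave unreadable from compound 2 to compound 3. Compound 1 therefore stands at the limit, and the two other values share that place with it.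

Compound 4, `CC(C)Sc1nc(N)nc2c1ncn2/C=C1/CC1(CO)CO`, differs from compound 1 in one place: isopropylsulfanyl in place of 2-methoxyethoxy on an aromatic carbon. The three measured steps all concern a saturated chain carbon some bonds along from an oxygen on an aromatic ring, and none of them is readable in size, so they give neither a direction nor a magnitude to expect. The estimated step is a step that the limit leaves unreadable from compound 1 to compound 4, that is, nothing beyond the usual scatter. Compound 4 is thus expected to give about 30000 nM, within a range from 12000 nM to 100000 nM, most probably reported again only as a limit.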

Compound 4, half-maximal cytotoxic concentration: > 20000 nM
Compound 4: only a limit was reported; the forecaster's own chance of this, stated with the estimate: 85%; the middle value is on the limit's open side.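

In this assay, compound 4 also gives only a limit (> 20000 nM). Among the compounds shown here, no step from compound 1, compound 2 or compound 3 to compound 4 can be read, because all four stop at the same point: (the limit of > 20000 nM in this assay, at which 4 of the 4 values shown sit). Going by these compounds, whether isopropylsulfanyl in place of these ether chains changes toxicity at all, and in which direction, stays open.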